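Growing the side chain: from compound 3 to compound 4

The compounds below may be only part of what the source reports. "The series", "measured", "known", "first", "only" and "open" are said of these compounds alone.

Of the compounds shown here, three with a shared core have been tested in an ADME assay on HEL cells (Homo sapiens) for cytotoxicity, with a stated time of 3 days; a lower number here means that less compound is tolerated, a higher number that more compound is tolerated. Compound 1 `CCC1(Cc2ccccc2)OS(=O)(=O)C=C1OCc1ccccc1` gives 200000 nM in this assay. Compound 2 `CCC1(Cc2ccccc2)OS(=O)(=O)C=C1OCc1ccc([N+](=O)[O-])cc1` carries nitro in place of hydrogen on an aromatic carbon; in this assay compound 2 gives only a limit, < 200000 nM, not a number. For the measured compounds named here, compound 3 `CC1(Cc2ccccc2)OS(=O)(=O)C=C1OCc1ccccc1` has hydrogen in place of methyl on a saturated chain carbon bound to a saturated ring carbon, and in this assay compound 3 gives 68000 nM, the lowest of the two numbers known. The step of a 2.9-fold lower number from compound 1 to compound 3 (0.47 log units; beyond the scatter) is modest and beyond the scatter, while the step of a number no higher from compound 1 to compound 2 (the limit leaves the size open) leaves its size open.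

Compound 4 `CC(C)CC1(Cc2ccccc2)OS(=O)(=O)C=C1OCc1ccccc1` is not yet measured. It differs from compound 3 in one place: isopropyl in place of hydrogen on a saturated chain carbon bound to a saturated ring carbon. Going by the values given here, only the step from compound 1 to compound 3 touches that place, and there the shorter chain gave the lower number. Compound 4, with the longer chain, is therefore expected to move upward, a 2.9-fold higher number from compound 3 to compound 4 (0.47 log units; beyond the scatter), by an uncertain amount. Compound 4 is estimated at 200000 nM, with a range from 70000 nM to 600000 nM. A limit is possible here too, given (the limit of < 200000 nM in this assay, at which 1 of the 3 values shown sits).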

Compound 4, half-maximal cytotoxic concentration: 102000 nM
The estimate for compound 4 lay 2.0-fold (0.29 log units) above the measured number; the measured number falls inside the stated range.
By their numbers in this assay, from the lowest: compounds 3, 4 and 1 (each within the scatter of the next, the first and the last beyond it).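

Putting isopropyl on this saturated chain carbon gives a 1.5-fold higher number from compound 3 to compound 4 (0.18 log units; within the scatter), and the swap of isopropyl for methyl at the same place gives a 2.0-fold lower number from compound 1 to compound 4 (0.29 log units; within the scatter), so in this assay compound 4 cannot be told apart from either of the other two. The clear gap between compound 1 and compound 3 therefore does not extend into a steady trend with chain size, as the larger, branched chain of compound 4 stands beyond the scatter of neither. Nothing measured here gives a cause for this result.

Going by these compounds, whether a longer straight chain at this place would behave like the isobutyl chain of compound 4 remains open. So does the effect of ending the chain in an amine or a carboxylic acid.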